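Bromo for Chloro in a Short Halogen Series

This account rests on a few compounds, and the source may have more. Where it says the series, first, only, none or still open, it means among the compounds named here.

Compound 3 `Clc1ccc(C2=NN(C3=NC(c4ccccc4)CS3)C(c3cccc4ccccc34)C2)cc1` carries a chloro group on an aromatic carbon of the shared core. In a functional assay on HepG2 cells (Homo sapiens) for inhibition, read by CCK-8 assay, with a stated time of 48 h (on this read-out lower numbers stand for stronger inhibition and higher numbers for weaker inhibition), compound 3 gives 18700 nM, the second highest of the three numbers recorded so far. Its nearest neighbour is compound 2 `Fc1ccc(C2=NN(C3=NC(c4ccccc4)CS3)C(c3cccc4ccccc34)C2)cc1`, which in this assay gives 23200 nM; the step of a 1.2-fold lower number from compound 2 to compound 3 (0.09 log units; within the scatter) lies within the scatter. The unsubstituted parent, compound 1 `c1ccc(C2=NN(C3=NC(c4ccccc4)CS3)C(c3cccc4ccccc34)C2)cc1`, gives 13200 nM in this assay, and the step of a 1.4-fold higher number from compound 1 to compound 3 (0.15 log units; within the scatter) is likewise within the scatter, as is a 1.8-fold higher number from compound 1 to compound 2 (0.24 log units; within the scatter).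

Compound 4 `Brc1ccc(C2=NN(C3=NC(c4ccccc4)CS3)C(c3cccc4ccccc34)C2)cc1` differs from compound 3 by bromo in place of chloro on an aromatic carbon. Within the data shown here, the steps that bear on this change are those in which a halogen was introduced or exchanged on the same aromatic carbon: a 1.4-fold higher number from compound 1 to compound 3 (0.15 log units; within the scatter), a 1.2-fold lower number from compound 2 to compound 3 (0.09 log units; within the scatter) and a 1.8-fold higher number from compound 1 to compound 2 (0.24 log units; within the scatter), none of them beyond the scatter. Hydrogen, fluoro and chloro at this carbon therefore gave numbers that cannot be told apart, and a bromo group is expected to behave in the same way. Compound 4 is accordingly expected to give about 20000 nM in this assay, with a range from 8000 nM to 50000 nM. The expected step of a 1.1-fold higher number from compound 3 to compound 4 (0.03 log units; within the scatter) amounts to no change beyond the scatter.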

Compound 4, half-maximal inhibitory concentration: 15600 nM
Compound 4: the middle estimate sits 1.3-fold (0.11 log units) above what was measured; the range from low to high includes it.
By their numbers in this assay, from the lowest: compounds 1, 4, 3 and 2 (each within the scatter of the next).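

In this assay, the bromo group leaves the number within the scatter of every earlier compound, with a 1.2-fold lower number from compound 3 to compound 4 (0.08 log units; within the scatter), a 1.5-fold lower number from compound 2 to compound 4 (0.17 log units; within the scatter) and a 1.2-fold higher number from compound 1 to compound 4 (0.07 log units; within the scatter). The earlier compounds had shown this only for hydrogen, fluoro and chloro; with 4-bromophenyl in place of 4-chlorophenyl, the series now shows that four different atoms on this aromatic carbon, para to a large group, cannot be told apart, and no order among the halogens can be read from these values. Nothing measured here speaks to what lies behind this flat result.

What stays open is whether a group of another kind on this same carbon, such as an amine, a carboxylic acid or a methoxy group, would move the number beyond the scatter, since hydrogen and the halogens alone are shown there. All four compounds also share the same core and differ only at this one carbon, so whether a change elsewhere on the shared core would alter the number, or alter this insensitivity to the halogen, also remains unanswered.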